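A solubility step from compound 2 to compound 4

The source may report more compounds than this note shows. Statements on the series, on what has been measured and on what is new or still open speak of the compounds shown alone.

Values measured in a physicochemical assay for solubility, read by HPLC, in simulated intestinal fluid, with a stated time of 16 h, at pH 6.5 (a higher number here means a more soluble compound, a lower number a less soluble compound), for three compounds:
- compound 1 (`CC(=O)Nc1c(F)cc(C(=O)N[C@H]2CC[C@H](O)CC2)cc1O[C@@H](C)c1ccccc1`) gives 996 ug/mL as a number
- compound 2 (`CNC(=O)c1cc(C(=O)N[C@H]2CC[C@H](O)CC2)c([C@@H](C)c2cccc(OC)c2)o1`) gives 868 ug/mL as a number
- compound 3 (`CNC(=O)c1cc(C(=O)N[C@H]2CC[C@H](OC)CC2)n([C@@H](CO)c2ccccc2)n1`) gives > 1000 ug/mL as a limit of the assay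

Compound 2 at 868 ug/mL stands within the scatter of its nearest neighbour, compound 1 at 996 ug/mL in this assay, so the two numbers cannot be told apart. Compound 3 offers no number for comparison, only the limit > 1000 ug/mL in the same measurement.

Compound 4 (`CNC(=O)c1cc(C(=O)N[C@H]2CC[C@H](O)CC2)c([C@@H](C)c2ccccc2Cl)o1`) has not yet been measured. It carries 2-chlorophenyl in place of 3-methoxyphenyl on a saturated chain carbon bound to an aromatic carbon and a saturated chain carbon. Among the compounds with values here, no two measured compounds differ in one place only, so the data show no precedent for this change in this assay. The expectation therefore starts from compound 2 at 868 ug/mL and allows for a small downward move. The estimated change a 1.4-fold lower number from compound 2 to compound 4 (0.16 log units; within the scatter) is expected to be modest. Compound 4 is expected at 600 ug/mL within a range of 200 ug/mL to 1000 ug/mL as an estimate.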

Compound 4, solubility: > 1000 ug/mL
Compound 4 gave a limit, no number; the forecaster's own chance of this, stated with the estimate: 15%; middle value at least 1.6-fold (0.22 log units) away from the limit.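

In this assay, within the data shown here, replacing 3-methoxyphenyl with 2-chlorophenyl on a saturated chain carbon bound to an aromatic carbon and a saturated chain carbon gives the only step that can be read in this set: an at least 1.1-fold higher number from compound 2 to compound 4 (0.06 log units; that floor lies within the scatter). Compound 4 gives > 1000 ug/mL, which is a limit of the assay and not a number. The result shows that this change, which leaves the hydrogen-bond acceptor of 3-methoxyphenyl out and brings in 2-chlorophenyl with none, produced no drop in solubility at this position, but the reading is bounded from one side only: the limit of > 1000 ug/mL in this assay, at which 2 of the 4 values shown sit.

Going by these compounds, how far compound 4 lies past its limit remains open, and so does whether the true step from 3-methoxyphenyl to 2-chlorophenyl goes beyond the scatter. Also open, on these data alone, is whether the step follows from the chlorine, from the place of the group on the phenyl ring or from the loss of the methoxy group, and how a phenyl ring carrying a carboxylic acid or an amine would read on this same carbon.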